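Acetoxy on the Prenyl Chain of a Quinone Core

The source may report more compounds than this note shows. Statements on the series, on what has been measured and on what is new or still open speak of the compounds shown alone.

The two measured compounds share a core and differ only in where the prenyl chain sits on it. Compound 1 `COc1ccc(O)c2c1C(=O)C=C(CCC=C(C)C)C2=O` was tested in an ADME assay on NIH3T3 cells (Mus musculus) for cytotoxicity, read by MTT assay, with a stated time of 48 h (on this read-out higher numbers stand for weaker inhibition and lower numbers for stronger inhibition), and gave 5180 nM. Compound 2 `COc1ccc(O)c2c1C(=O)C(CCC=C(C)C)=CC2=O` gave 6570 nM in this assay. Of the two numbers, compound 1 holds the lowest, but the gap to compound 2 lies within the usual scatter of repeated measurements, so the two values show no difference that can be read as an order.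

Compound 3 `COc1ccc(O)c2c1C(=O)C=C([C@H](CC=C(C)C)OC(C)=O)C2=O` is not yet measured. It differs from compound 1 in one place: acetoxy in place of hydrogen on a saturated chain carbon bound to a double-bonded ring carbon and a saturated chain carbon. Going by the values given here, no step between measured compounds of this kind is available, so the size of its effect on cytotoxicity in this assay cannot be drawn from the data.

Given that, a step from compound 1 to compound 3 is expected to be small, within or close to the scatter, and if anything toward a slightly lower number, as a 1.3-fold lower number from compound 1 to compound 3 (0.11 log units; within the scatter). For compound 3 in this assay the estimate is 4000 nM, with an expected range from 1500 nM to 12000 nM.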

Compound 3, half-maximal inhibitory concentration: 660 nM
For compound 3 the middle estimate is 6.1-fold (0.78 log units) above the measured one; measured number below the stated range.
By their numbers in this assay, from the lowest: compound 3; then compounds 1 and 2 (each within the scatter of the next).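

The chain carbon bound to a double-bonded ring carbon and a saturated chain carbon turns out to be a place where a single change registers. In this assay, acetoxy in place of hydrogen there gives a 7.8-fold lower number from compound 1 to compound 3 (0.89 log units; beyond the scatter), whereas the two earlier compounds, which differ only in where the prenyl chain sits, offered no difference that could be read as an order. Going by these compounds alone, this is therefore the first step to lie beyond the scatter, and it runs toward stronger inhibition on this read-out, though nothing at hand speaks to why the number moves.

The compounds shown leave open whether the step belongs to the acetoxy group itself or would also appear with a hydroxyl group or a longer ester such as butyryloxy at the same carbon, and whether the opposite spatial arrangement at that carbon would give a similar number. They also leave open whether acetoxy would have a comparable effect on the chain of compound 2, where the prenyl chain sits elsewhere on the shared core.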